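A few compounds are considered here, and "the series" means these few. Any claim that something is new, unique, unknown or untested is made for them only; others in the source may bear on it.

Measured in a functional assay on the whole organism for inhibition, with Lemna aequinoctialis as the target, tested at 10 ug/mL; a higher number here means more inhibition of growth at the concentration tested, a lower number less inhibition of growth:
- compound 1 `Cc1ccc(NC(=S)N/N=C2\C(=O)Nc3ccc([N+](=O)[O-])cc32)cc1`: 15%
- compound 2 `O=C1Nc2ccc([N+](=O)[O-])cc2/C1=N/NC(=S)Nc1ccccc1C(F)(F)F`: 10%

Compound 1 and compound 2 lie within the scatter of each other, so compound 1 does not stand apart on these two numbers. Compound 3 `O=C1Nc2ccc([N+](=O)[O-])cc2/C1=N/NC(=S)Nc1ccc(I)cc1` is compound 1 with iodo in place of methyl on an aromatic carbon, para to a large group: iodo in place of methyl on an aromatic carbon. Among the measured compounds shown here, no measured single-place step exists to calibrate this change. In this assay, no change beyond the scatter is expected. The expected step is a number 1 percentage points lower from compound 1 to compound 3 (within the scatter). For compound 3 the estimated value is 14%, with an expected range of 3% to 30%.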

Compound 3, percent growth inhibition at one concentration: 5%
Compound 3: the middle estimate sits 9 percentage points above what was measured, and the stated range covers the measured number.
By their numbers in this assay, from the lowest: compounds 3, 2 and 1 (each within the scatter of the next).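

Iodo in place of methyl on an aromatic carbon, para to a large group, gives the first single-place step of the series in this assay, and it reads a number 10 percentage points lower from compound 1 to compound 3 (within the scatter). At this position, then, the exchange moves the read-out by no more than the scatter, and this single step sets no trend. Nothing available bears on the reason for this result.

From the compounds shown here alone, whether an amine, a carboxylic acid or a longer chain at this position would shift growth inhibition beyond the scatter remains open. So does the effect of replacing the nitro group on the shared core.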